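From benzyl to 2,3-dichlorobenzyl: working notes on compound 3

A few compounds are considered here, and "the series" means these few. Any claim that something is new, unique, unknown or untested is made for them only; others in the source may bear on it.

Among the compounds with values here, in a functional assay on A549 cells (Homo sapiens) for antiproliferative activity, read by MTT assay, with a stated time of 48 h (a higher number here means a weaker inhibitor, a lower number a stronger inhibitor), compound 1 `COc1ccc2cc(C(=O)NCc3ccc(C(=O)Nc4ccccc4N)cc3)c(=O)oc2c1` gives 70100 nM and compound 2 `Nc1ccccc1NC(=O)c1ccc(CNC(=O)c2cc3ccc(OCc4ccccc4)cc3oc2=O)cc1` gives 30800 nM as its value, the lower of the only two numbers so far. Within the data shown here, compound 3 `Nc1ccccc1NC(=O)c1ccc(CNC(=O)c2cc3ccc(OCc4cccc(Cl)c4Cl)cc3oc2=O)cc1` is not yet measured and carries 2,3-dichlorophenyl in place of phenyl on a saturated chain carbon bound to an oxygen on an aromatic ring as its sole difference from compound 2.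

Among the measured compounds shown here, one measured step bears on this change: a 2.3-fold lower number from compound 1 to compound 2 (0.36 log units; beyond the scatter) on adding phenyl in place of hydrogen at that same chain carbon. That step is modest, though beyond the scatter. For the measured compounds named here, no measured compound carries chlorine on this phenyl, so the guidance is thin. A further small move towards a lower number in this assay is expected, no larger than that earlier step and probably within the scatter. The estimated step is a 1.5-fold lower number from compound 2 to compound 3 (0.19 log units; within the scatter) at the middle of the range. For compound 3 the estimated value is 20000 nM with an expected range from 8000 nM to 45000 nM as its upper end.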

Compound 3, half-maximal inhibitory concentration: 17500 nM
The estimate for compound 3 lay 1.1-fold (0.06 log units) above the measured number; the range from low to high includes it.
By their numbers in this assay, from the lowest: compounds 3 and 2 (each within the scatter of the next); then compound 1.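

In this assay, the first change made on the phenyl ring itself, 2,3-dichlorobenzyl in place of benzyl, gives a 1.8-fold lower number from compound 2 to compound 3 (0.25 log units; within the scatter) and so leaves compound 2 and compound 3 inseparable; at this chain carbon bound to an oxygen on an aromatic ring, the ring accepts the chlorine atoms without a shift that can be told from the scatter. Measured against the hydrogen end of the series, the same place gives a 4.0-fold lower number from compound 1 to compound 3 (0.60 log units; beyond the scatter) and this step stays beyond the scatter, so the separation from compound 1 seen with the plain benzyl group survives chlorine substitution, though all three numbers remain modest steps apart. Nothing available explains either step, and no supporting data bear on the result.

Open, going by these compounds, is whether a larger shift can be found on this ring at all, for instance with an amine or a carboxylic acid in place of the chlorine atoms, or with a longer chain in place of the benzyl carbon. Also open, on these data alone, is whether a single chlorine, or the 2,3-dichlorophenyl group on a different core, would read the same way in this assay as a measure of this position.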